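The compounds below may be only part of what the source reports. "The series", "measured", "known", "first", "only" and "open" are said of these compounds alone.

Values in an assay on M10 cells (Gallus gallus) for binding affinity to Neuronal acetylcholine receptor; alpha4/beta2 (Homo sapiens); on this read-out lower numbers stand for stronger inhibition and higher numbers for weaker inhibition:

compound 1 `[N-]=[N+]=Nc1cc(Cl)ncc1Cn1ccsc1=N`: 110 nM
compound 2 `[N-]=[N+]=Nc1ccncc1Cn1ccsc1=N`: 820 nM
compound 3 `[N-]=[N+]=Nc1cncc(Cn2ccnc2N[N+](=O)[O-])c1`: 5400 nM

Compound 3 gives the highest number of the three, with gaps to compound 2 and compound 1 that lie beyond the scatter. How the core of compound 3 differs from that of compound 2 is not broken down here. Within the shared core of compound 1 and compound 2, the single change chloro in place of hydrogen on an aromatic carbon made the step of a 7.5-fold lower number from compound 2 to compound 1 (0.87 log units; beyond the scatter).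

Compound 4 `[N-]=[N+]=Nc1cc(Cn2ccnc2N[N+](=O)[O-])cnc1Cl` carries the same kind of change relative to compound 3, namely (chloro in place of hydrogen on an aromatic carbon), but the surroundings differ: here the chloro sits ortho to an azido group and para to a large group, whereas in compound 1 it sits meta to an azido group and para to a group of 7 heavy atoms. On the strength of the step seen from compound 2 to compound 1, a step of comparable direction in this assay is expected, though the different place leaves the size less certain; the estimated step is a 5.4-fold lower number from compound 3 to compound 4 (0.73 log units; beyond the scatter). Compound 4 is therefore expected to give about 1000 nM, between 400 nM and 3000 nM.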

Compound 4, inhibition constant: 300 nM
Compound 4: the middle estimate sits 3.3-fold (0.52 log units) above what was measured, and the stated range ends above it.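

In this assay, chloro in place of hydrogen on an aromatic carbon gives an 18-fold lower number from compound 3 to compound 4 (1.26 log units; beyond the scatter), and this step agrees in direction and size with the earlier one: the same change on two cores in this assay, a 7.5-fold lower number (0.87 log units; beyond the scatter) from compound 2 to compound 1 and an 18-fold lower number (1.26 log units; beyond the scatter) from compound 3 to compound 4, 2.4-fold (0.38 log units) apart, within the scatter of two such steps. The change therefore carries over between these two cores, even though the chloro stands in a different place on each. Two cores establish no rule for the wider series, and these pairs do not separate the effect of the core from that of the chloro's place.

The compounds shown compare only hydrogen and chloro, so it remains open whether bromo, methyl or an amine would give a step in the same direction. Going by these compounds, whether the chloro step holds on other cores also remains open.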